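The source may hold more compounds than are shown below. What is called first, only, known or untested is meant among the compounds shown, and "the series" means these compounds.

Series notes on the piperidine dienamides.

For the measured compounds named here, in an assay for inhibition of Polyunsaturated fatty acid 5-lipoxygenase (Homo sapiens), read by spectrophotometry, tested at 20 uM (on this read-out higher numbers stand for more inhibition at the one concentration tested (going by the name of the read-out) and lower numbers for less inhibition), compound 1 `O=C(/C=C/C=C/c1ccc(Cl)cc1)N1CCCCC1` gives 14.5% and stands lowest of the three measured members. Compound 2 `COc1cc(/C=C/C=C/C(=O)N2CCCCC2)cc(OC)c1` gives 64.9% in this assay, a number beyond the scatter above compound 1, and compound 3 `COc1cc(OC)c(/C=C/C=C/C(=O)N2CCCCC2)c(OC)c1` gives 77.1%, the furthest from compound 1. Going by the values given here, no single-change step between measured compounds is available, so the effect of removing a ring substituent alone has not been measured.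

Compound 4 `O=C(/C=C/C=C/c1ccccc1)N1CCCCC1` differs from compound 1 by hydrogen in place of chloro on an aromatic carbon. Among the compounds with values here, with no measured step to lean on, the expected change from compound 1 to compound 4 is a number 3.5 percentage points lower from compound 1 to compound 4 (within the scatter), a shift judged to lie within the scatter or slightly downward. Compound 4 is therefore estimated at 11% in this assay, with a range from 0% to 28%.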

Compound 4, a percentage reported as inhibition, at one concentration (the size of the read-out at that concentration, not a potency): 36.3%
Beside the measured number, compound 4's estimate is 25.3 percentage points below it; the whole stated range lies below it.
By their numbers in this assay, from the lowest: compound 1; then compound 4; then compound 2; then compound 3.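

Hydrogen in place of chloro on an aromatic carbon, para to a large group, gives a number 21.8 percentage points higher from compound 1 to compound 4 (beyond the scatter) in this assay as the first single-change step in the series. Chloro at this place therefore goes with less inhibition than hydrogen, an effect that the earlier compounds, differing in several places, could not isolate. No available data explain this step.

Open, as far as these compounds go, is whether a single methoxy, an amine or a carboxylic acid at this place would give a number above or below that of compound 4. Also open, from the compounds shown here alone, is whether the chloro step holds when the ring carries further substituents.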